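Swapping Chloro for Bromo on a Shared Core

The compounds below may be only part of what the source reports. "The series", "measured", "known", "first", "only" and "open" are said of these compounds alone.

Two measured compounds share one core and differ in their side groups. Compound 1 `COC(=O)C1=C(N)Oc2ccc(Cl)cc2C1CC(=O)c1ccccc1` carries a methyl ester, while compound 2 `Cc1ccc(C(=O)CC2C(C#N)=C(N)Oc3ccc(Cl)cc32)cc1` carries a nitrile and a methyl group on its outer ring. In a functional assay on MCF7 cells (Homo sapiens) for antiproliferative activity, read by sulforhodamine B assay, with a stated time of 72 h, tested at 10 uM (on this read-out higher numbers stand for a weaker effect at the one concentration tested and lower numbers for a stronger effect), compound 1 gives 87.2% and compound 2 gives 85.5%. These two numbers sit within the scatter of each other, so neither compound can be called the stronger or the weaker of the pair. Compound 3 `Cc1ccc(C(=O)CC2C(C#N)=C(N)Oc3ccc(Br)cc32)cc1` differs from compound 2 in a single place: bromo in place of chloro on an aromatic carbon. Within the data shown here, no measured pair in this set shows what such a swap does to the read-out, so there is no basis for expecting a shift beyond the scatter. The expected step is therefore a number 0.5 percentage points lower from compound 2 to compound 3 (within the scatter). On that basis compound 3 is estimated to give about 85%, with a likely range from 70% to 96%.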

Compound 3, a percentage reported as activity, at one concentration (the size of the read-out at that concentration, not a potency): 69%
The estimate for compound 3 lay 16 percentage points above the measured number; the whole stated range lies above it.
By their numbers in this assay, from the lowest: compound 3; then compounds 2 and 1 (each within the scatter of the next).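

Bromo in place of chloro on this aromatic carbon gives a number 16.5 percentage points lower from compound 2 to compound 3 (beyond the scatter) in this assay, so this position on the shared core can affect the read-out. Among these compounds, this is the first single-place change in the set, and it moves the number beyond the usual scatter even though the two groups count the same under the computed comparison: one heavy atom each, no ring, no hydrogen-bond donor or acceptor and no net charge. Nothing available explains why bromo gives the stronger effect at the one concentration tested.

Going by these compounds, it remains open whether fluoro, iodo or an amine on this same carbon would give a lower or higher number. On these data alone, it also remains open whether the same swap would give a similar step on compound 1, which carries a methyl ester.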